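Working notes on the triazolylmethyl amide series: compound 4

The compounds below may be only part of what the source reports. "The series", "measured", "known", "first", "only" and "open" are said of these compounds alone.

The series shares the core shown for compound 1 `Cc1ccc(-n2cc(CNC(=O)c3cccc4c3cnn4C(C)C)nn2)cc1C`; compound 2 `CC(C)n1ncc2c(C(=O)NCc3cn(-c4ccc(I)cc4)nn3)cccc21` and compound 3 `CC(C)n1ncc2c(C(=O)NCc3cn(-c4ccc(F)cc4)nn3)cccc21` vary the aryl group on the aromatic nitrogen. In a functional assay on MGC-803 cells (Homo sapiens) for inhibition, read by MTT assay, with a stated time of 72 h (a lower number here means a stronger inhibitor, a higher number a weaker inhibitor), compound 1 gives > 40000 nM, which is a limit of the assay and not a number. In this assay compound 2 gives > 40000 nM, again a limit. Compound 3 gives > 40000 nM in this assay, also a limit. Since (the limit of > 40000 nM in this assay, at which 3 of the 3 values shown sit), the steps a step that the two limits leave unreadable from compound 1 to compound 2, a step that the two limits leave unreadable from compound 1 to compound 3 and a step that the two limits leave unreadable from compound 2 to compound 3 cannot be read. Compound 3 therefore stands at the limit, with nothing in the numbers to set it apart from the other two.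

Compound 4 `CC(C)n1ncc2c(C(=O)NCc3cn(-c4cccc(Br)c4)nn3)cccc21` carries 3-bromophenyl in place of 4-fluorophenyl on an aromatic nitrogen. Within the data shown here, none of the measured steps bears on this change in a readable way; all three measured members sit at the limit. Expected is a number no higher from compound 3 to compound 4 (the limit leaves the size open), none beyond the scatter, with a limit the most likely outcome. Compound 4 is estimated at 40000 nM in this assay, within 8000 nM to 200000 nM.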

Compound 4, half-maximal inhibitory concentration: > 40000 nM
Compound 4: a limit, no number (the forecaster's own chance of this, stated with the estimate: 80%); the middle value lies on the limit itself.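

No new step can be read from compound 4 to compound 1, compound 2 or compound 3, because all four compounds stand at one limit: the limit of > 40000 nM in this assay, at which 4 of the 4 values shown sit.

The compounds shown leave open whether any aryl group on this aromatic nitrogen of the shared core gives a readable number in this assay, and how these four aryl groups would rank.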